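A few compounds are considered here, and "the series" means these few. Any claim that something is new, unique, unknown or untested is made for them only; others in the source may bear on it.

Compound 2, `C=CC(=O)N1CC[C@H](N2C(=O)N(C3CCCC3)Cc3cnc(Nc4ccc(N5CCN(C)CC5)cc4OC)nc32)C1`, is studied in a physicochemical assay for solubility, read by HPLC, in phosphate buffer, measured as thermodynamic solubility, with a stated time of 24 h, at pH 6.8; a higher number here means a more soluble compound, a lower number a less soluble compound. Among the three compounds with numbers, compound 2 gives 250 ug/mL, the lowest of them. Compound 1, `C=CC(=O)N1CC[C@H](N2C(=O)N(C(C)C)Cc3cnc(Nc4ccc(N5CCN(C)CC5)cc4OC)nc32)C1`, gives 2490 ug/mL, and compound 3, `C=CC(=O)N1CC[C@H](N2C(=O)N(c3ccccc3)Cc3cnc(Nc4cccc(N5CCN(C)CC5)c4)nc32)C1`, gives 714 ug/mL. Compound 4, `C=CC(=O)N1CC[C@H](N2C(=O)N(c3ccccc3)Cc3cnc(Nc4ccc(N5CCN(C)CC5)cc4OC)nc32)C1`, differs from compound 2 in one place: phenyl in place of cyclopentyl on an amide-type nitrogen in a ring. Among the measured compounds shown here, the single step that bears on this position, a 10-fold lower number from compound 1 to compound 2 (1.00 log units; beyond the scatter), shows that the group on this ring nitrogen can move the number a long way. For the measured compounds named here, compound 3 also carries phenyl at that nitrogen, but its other part differs, so no direct step is known. Because of a 10-fold lower number from compound 1 to compound 2 (1.00 log units; beyond the scatter) and the numbers of compound 3, a modest rise is expected, a 1.8-fold higher number from compound 2 to compound 4 (0.26 log units; within the scatter), and compound 4 is estimated at 450 ug/mL, between 150 ug/mL and 1300 ug/mL.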

Compound 4, solubility: 1540 ug/mL
Compound 4: middle estimate off by 3.4-fold (0.53 log units), on the low side, outside the stated range (above it).
By their numbers in this assay, from the lowest: compound 2; then compound 3; then compounds 4 and 1 (each within the scatter of the next).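

In this assay, among the compounds shown here, phenyl in place of cyclopentyl on the amide-type nitrogen gives a 6.2-fold higher number from compound 2 to compound 4 (0.79 log units; beyond the scatter) and is the first direct comparison of two rings at this position. Phenyl in place of isopropyl gives a 1.6-fold lower number from compound 1 to compound 4 (0.21 log units; within the scatter) so, among these three groups, only cyclopentyl stands apart. No measured evidence explains this difference. The compounds shown leave open how an amine or a longer carbon chain on this nitrogen would compare. They also leave open whether cyclohexyl would sit with cyclopentyl or with phenyl.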